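Chloro to Fluoro Swap Across Two Related Cores

The source may report more compounds than this note shows. Statements on the series, on what has been measured and on what is new or still open speak of the compounds shown alone.

Compound 1 `COC(=O)C(=N)/C=C(\O)c1ccc(Cl)cc1` and compound 3 `N/C(=C\C(=O)c1ccc(Cl)cc1)C(=O)O` differ in more than one place, and the difference between their two cores is not broken down here. In an assay for inhibition of kynurenine 3-monooxygenase (Rattus norvegicus), tested at 10 uM (a lower number here means less inhibition, a higher number more inhibition at the concentration tested (going by the name of the read-out)), compound 1 gives 13%, while compound 3 gives 33%. Compound 2 `COC(=O)C(=N)/C=C(\O)c1ccc(F)cc1` is obtained from compound 1 by fluoro in place of chloro on an aromatic carbon, and in this assay compound 2 gives 1%, so that a number 12 percentage points lower from compound 1 to compound 2 (beyond the scatter). Compound 4 `N/C(=C\C(=O)c1ccc(F)cc1)C(=O)O` stands to compound 3 by fluoro in place of chloro on an aromatic carbon. This is the same kind of change, though not the same: in compound 1 the site is para to a group of 9 heavy atoms, in compound 3 it is para to a group of 8 heavy atoms. The expectation rests on a number 12 percentage points lower from compound 1 to compound 2 (beyond the scatter), and a step of similar size is expected in this assay, namely a number 12 percentage points lower from compound 3 to compound 4 (beyond the scatter). Compound 4 is accordingly estimated at 21%, expected to fall between 6% and 34%.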

Compound 4, a percentage reported as inhibition, at one concentration (the size of the read-out at that concentration, not a potency): 41%
The estimate for compound 4 lay 20 percentage points below the measured number, and the stated range ends below it.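

In this assay, fluoro in place of chloro on an aromatic carbon did not behave alike on the two cores: the same change on two cores in this assay, a number 12 percentage points lower (beyond the scatter) from compound 1 to compound 2 and a number 8 percentage points higher (within the scatter) from compound 3 to compound 4, 20 percentage points apart, beyond the scatter of two such steps. On the core of compound 3 the change gave a number 8 percentage points higher from compound 3 to compound 4 (within the scatter), so the lower number seen on the core of compound 1 cannot be assumed to carry over to that core. Among these compounds, with only one pair on each core, this shows that the step differs between these two pairs, but it does not show which of the differences between the cores accounts for it.

The compounds shown leave open how the two cores would compare with bromo or methoxy at that place, or with no substituent there at all. They also leave open whether a group such as an amine would separate the cores in the same way.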